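Removing the meta-methoxy group from compound 2

The compounds below may be only part of what the source reports. "The series", "measured", "known", "first", "only" and "open" are said of these compounds alone.

Compound 2 `COc1ccc(-c2nc(C)c(C(=O)CSc3nc(-c4cccc(OC)c4)c(C#N)c(=O)[nH]3)s2)cc1` stands lowest of the three numbers measured in a functional assay on U-87MG ATCC cells for antiproliferative activity against U-87 MG (Homo sapiens), read by MTT assay, with a stated time of 48 h, tested at 10 uM (on this read-out lower numbers stand for a stronger effect and higher numbers for a weaker effect at the one concentration tested), at 66.7%. Its nearest neighbour is compound 1 `COc1ccc(-c2nc(C)c(C(=O)CSc3nc(-c4ccc(OC)cc4)c(C#N)c(=O)[nH]3)s2)cc1`, which in this assay gives 80.3%, and the furthest is compound 3 `COc1cccc(-c2nc(SCC(=O)c3sc(-c4ccccc4)nc3C)[nH]c(=O)c2C#N)c1`, which gives 90.2%. Both gaps lie beyond the scatter: a number 13.6 percentage points lower from compound 1 to compound 2 (beyond the scatter) and a number 23.5 percentage points higher from compound 2 to compound 3 (beyond the scatter).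

Compound 4 `COc1ccc(-c2nc(C)c(C(=O)CSc3nc(-c4ccccc4)c(C#N)c(=O)[nH]3)s2)cc1` has not yet been measured in this assay. It differs from compound 2 in one place: hydrogen in place of methoxy on an aromatic carbon. The same kind of change, though at another aromatic carbon, as the two structures show, has already been seen once: a number 23.5 percentage points higher from compound 2 to compound 3 (beyond the scatter), a modest rise beyond the scatter. Within the data shown here, no other measured step bears directly on it; the step of a number 13.6 percentage points lower from compound 1 to compound 2 (beyond the scatter) concerns the position of a methoxy group rather than its removal.

Among the measured compounds shown here, from the one step that matches, compound 4 is expected to show a higher number than compound 2 in this assay, with the change estimated as a number 15.3 percentage points higher from compound 2 to compound 4 (beyond the scatter). The estimate for compound 4 in this assay is therefore 82%, with a range from 68% to 96%.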

Compound 4, a percentage reported as activity, at one concentration (the size of the read-out at that concentration, not a potency): 90.9%
Compound 4: middle estimate off by 8.9 percentage points, on the low side, within the range that was stated.
By their numbers in this assay, from the lowest: compound 2; then compounds 1, 3 and 4 (each within the scatter of the next, the first and the last beyond it).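

In this assay, among these compounds, the change from 3-methoxyphenyl to phenyl gives a number 24.2 percentage points higher from compound 2 to compound 4 (beyond the scatter), so the methoxy group on this ring counts just as the one on the other aromatic ring of compound 2 does, a point the earlier compounds could not show. The change from 4-methoxyphenyl to phenyl gives a number 10.6 percentage points higher from compound 1 to compound 4 (beyond the scatter), so a methoxy group at either of these two places on this ring gives a lower number than hydrogen does, with the 3-methoxyphenyl of compound 2 giving the lowest number of all the compounds shown. Removing a methoxy group raised the number in all three steps of this kind, and the two steps on different cores agree in size: the same change on two cores in this assay, a number 23.5 percentage points higher (beyond the scatter) from compound 2 to compound 3 and a number 10.6 percentage points higher (beyond the scatter) from compound 1 to compound 4, 12.9 percentage points apart, within the scatter of two such steps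

The compounds shown leave open whether an ethoxy group, a hydroxyl group or an amine at this place on the ring would hold the number at the level of compound 2 or take it lower. Going by these compounds, all of these read-outs come from a single concentration, so how the compounds compare in potency also remains open.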